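This account rests on a few compounds, and the source may have more. Where it says the series, first, only, none or still open, it means among the compounds named here.

Compound 1 `CC(=O)c1ccc(NC(=O)C(CC(C)C)N(C(=O)c2ccccc2)S(=O)(=O)c2ccc(C)cc2)cc1`, tested in a functional assay for inhibition, read by spectrophotometry, with a stated time of 20 min, tested at 1 mg/mL (on this read-out higher numbers stand for a stronger effect at the one concentration tested and lower numbers for a weaker effect), gives 54%. Compound 2 `CC(=O)c1ccc(NC(=O)C(C(C)C)N(C(=O)c2ccccc2)S(=O)(=O)c2ccc(C)cc2)cc1`, which carries an isopropyl in place of the isobutyl on the saturated chain carbon bound to an amide-type nitrogen and a carbonyl carbon, gives 15.6% in this assay. Among the measured compounds shown here, that single change produced a number 38.4 percentage points lower from compound 1 to compound 2 (beyond the scatter), a drop well beyond the scatter, so compound 2 stands lowest of the two numbers known so far, with compound 1 the only neighbour and well above it.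

Compound 3 `CC(=O)c1ccc(NC(=O)C(C(C)C)N(C(=O)c2ccccc2)S(=O)(=O)c2ccccc2)cc1` keeps the isopropyl of compound 2 and differs from it in one place only: hydrogen in place of methyl on an aromatic carbon, that is, a (4-methylphenyl)sulfonyl becomes a phenylsulfonyl. For the measured compounds named here, no measured step touches this part of the molecule; the one step known concerns the chain carbon, not the sulfonyl ring, so it offers no direct guide. With nothing pointing to a large move, the expectation is a step of a number 0.6 percentage points lower from compound 2 to compound 3 (within the scatter), within the scatter. Compound 3 is therefore estimated at 15% in this assay, in a range from 4% to 32%.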

Compound 3, a percentage reported as inhibition, at one concentration (the size of the read-out at that concentration, not a potency): 32.1%
The estimate for compound 3 lay 17.1 percentage points below the measured number, and the stated range ends below it.
By their numbers in this assay, from the lowest: compound 2; then compound 3; then compound 1.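

The aromatic carbon para to a large group on the sulfonyl ring is not a silent position: hydrogen in place of methyl there gives a number 16.5 percentage points higher from compound 2 to compound 3 (beyond the scatter) in this assay, so the removal of a single carbon is enough to move the read-out. Until now the only place shown to respond was the saturated chain carbon, where the change gave a number 38.4 percentage points lower from compound 1 to compound 2 (beyond the scatter); with this result, two separate parts of the molecule are seen to affect the number, and here the methyl is the form with the lower reading. Nothing available explains why the number rises when this methyl leaves, so the result stands as an observation only.

The compounds shown leave open whether hydrogen in place of methyl would raise the number in the same way when the chain carries the isobutyl of compound 1 rather than the isopropyl of compound 2. They also leave open how a chlorine, a methoxy or an amine on the same aromatic carbon would compare with the methyl and the hydrogen.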